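The source may hold more compounds than are shown below. What is called first, only, known or untested is meant among the compounds shown, and "the series" means these compounds.

Three compounds were measured in a functional assay on HepG2 cells (Homo sapiens) for cytotoxicity, read by MTT assay, with a stated time of 72 h; a lower number here means a stronger inhibitor, a higher number a weaker inhibitor. Compound 1 `[O-][S+](CCCCCN=C=S)Cc1ccccc1` gives 3910 nM in this assay. Compound 2 `CC(C)[S+]([O-])CCCCCN=C=S` gives 3690 nM in this assay; the difference between the cores of compound 1 and compound 2 is not broken down here. Compound 3 `[O-][S+](CCCCCCN=C=S)Cc1ccccc1` gives 6170 nM in this assay. Compound 3 differs from compound 1 by the change (a group of 4 heavy atoms (2 carbon, 1 nitrogen, 1 sulfur; no ring) in place of a group of 3 heavy atoms (1 carbon, 1 nitrogen, 1 sulfur; no ring), on a saturated chain carbon, five bonds along the chain from a sulfur), and the step of a 1.6-fold higher number from compound 1 to compound 3 (0.20 log units; within the scatter) shows how little that change did. Compound 4 `CC(C)[S+]([O-])CCCCCCN=C=S` has not yet been measured; it differs from compound 2 by the same change, (a group of 4 heavy atoms (2 carbon, 1 nitrogen, 1 sulfur; no ring) in place of a group of 3 heavy atoms (1 carbon, 1 nitrogen, 1 sulfur; no ring), on a saturated chain carbon, five bonds along the chain from a sulfur). Because the step of a 1.6-fold higher number from compound 1 to compound 3 (0.20 log units; within the scatter) was small, a step of similar size is expected here, a 1.5-fold higher number from compound 2 to compound 4 (0.17 log units; within the scatter). On that basis compound 4 is expected to give about 5500 nM in this assay, within an estimated range from 3000 nM to 10000 nM.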

Compound 4, half-maximal inhibitory concentration: 7820 nM
Compound 4: the middle estimate sits 1.4-fold (0.15 log units) below what was measured; measured number inside the range.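

Swapping the group of 3 heavy atoms (1 carbon, 1 nitrogen, 1 sulfur; no ring) for the group of 4 heavy atoms (2 carbon, 1 nitrogen, 1 sulfur; no ring) gives, in this assay, a 2.1-fold higher number from compound 2 to compound 4 (0.33 log units; beyond the scatter). The steps on the two cores do not differ: the same change on two cores in this assay, a 1.6-fold higher number (0.20 log units; within the scatter) from compound 1 to compound 3 and a 2.1-fold higher number (0.33 log units; beyond the scatter) from compound 2 to compound 4, 1.3-fold (0.13 log units) apart, within the scatter of two such steps. Within the data shown here, this shows that the change carried over between these two cores with a step of comparable size, but it rests on only two pairs and does not show that the same would hold on any other core.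

The compounds shown leave open what a longer chain would give on either core. They also leave open whether an amine or a carboxylic acid in place of these groups would give a similar number.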